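Restoring a piperidine ring on the glycinamide carbonyl

The compounds below may be only part of what the source reports. "The series", "measured", "known", "first", "only" and "open" are said of these compounds alone.

Compound 2 `COC(=O)CCNC(=O)CN1CN(c2ccccc2)C2(CCN(C(=O)c3ccc(C4CCCCC4)cc3)CC2)C1=O` stands highest of the two numbers in an assay on HEK293 cells for displacement of a labelled ligand from NPC1-like intracellular cholesterol transporter 1 (Homo sapiens) (a higher number here means a weaker inhibitor, a lower number a stronger inhibitor), where compound 2 gives 12900 nM; its nearest neighbour is compound 1 `CCC1CCCN(C(=O)CN2CN(c3ccccc3)C3(CCN(C(=O)c4ccc(C5CCCCC5)cc4)CC3)C2=O)C1`, which in this assay gives 2600 nM. Compound 3 `CCOC(=O)C1CCCN(C(=O)CN2CN(c3ccccc3)C3(CCN(C(=O)c4ccc(C5CCCCC5)cc4)CC3)C2=O)C1` carries 3-(ethoxycarbonyl)piperidin-1-yl in place of (2-(methoxycarbonyl)ethyl)amino on a carbonyl carbon. Among the measured compounds shown here, the one measured step that bears on this change is a 5.0-fold higher number from compound 1 to compound 2 (0.70 log units; beyond the scatter), which ran in the opposite direction, from a piperidine ring to an open chain. The step from compound 2 to compound 3 is therefore expected to lower the number, with the retained ester perhaps muting the gain, by a 3.7-fold lower number from compound 2 to compound 3 (0.57 log units; beyond the scatter). Compound 3 is estimated at 3500 nM, ranging from 1200 nM to 10000 nM.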

Compound 3, half-maximal inhibitory concentration: 4200 nM
Compound 3: middle estimate off by 1.2-fold (0.08 log units), on the low side, and the stated range covers the measured number.
By their numbers in this assay, from the lowest: compounds 1 and 3 (each within the scatter of the next); then compound 2.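

With the ester retained, 3-(ethoxycarbonyl)piperidin-1-yl in place of (2-(methoxycarbonyl)ethyl)amino gives a 3.1-fold lower number from compound 2 to compound 3 (0.49 log units; beyond the scatter) in this assay, so an ester on this group does not by itself keep the number as high as in compound 2. On the saturated ring carbon, ethoxycarbonyl in place of ethyl gives a 1.6-fold higher number from compound 1 to compound 3 (0.21 log units; within the scatter) and so leaves no readable difference. Nothing available explains either step. Open, as far as these compounds go, is whether a carboxylic acid or an amine on that ring carbon would also stay within the scatter of compound 1, and how the unsubstituted piperidin-1-yl group would compare.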